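Cyclobutyl in place of isopropyl at the ring nitrogen

The compounds below may be only part of what the source reports. "The series", "measured", "known", "first", "only" and "open" are said of these compounds alone.

Measured so far:
compound 1, `CC(C)n1cnc2c(N)ncnc21`, gives 16000 nM
compound 2, `CC(C)n1cnc2ncnc(N)c21`, gives > 30000 nM
compound 3, `CCC(C)n1cnc2ncnc(N)c21`, gives > 30000 nM

Among the compounds with values here, in a functional assay on CHO cells for antagonist activity at adenosine receptor A2b (Homo sapiens) (on this read-out higher numbers stand for weaker inhibition and lower numbers for stronger inhibition), compound 1 gives 16000 nM, the only real number among the three measured compounds. For compound 2 the value > 30000 nM is a limit of the assay, not a number. For compound 3 the value > 30000 nM is likewise a limit. Within the data shown here, the one change between two measured compounds, a step that the two limits leave unreadable from compound 2 to compound 3, therefore cannot be sized, since both of its ends rest at the limit of > 30000 nM in this assay, at which 2 of the 3 values shown sit.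

Compound 4, `Nc1ncnc2c1ncn2C1CCC1`, differs from compound 1 by cyclobutyl in place of isopropyl on an aromatic nitrogen. Among the measured compounds shown here, no measured step concerns an exchange of this kind, and the single known step gives no readable size. With nothing pointing either way, the expected step is one that stays inside the usual scatter: no change at the digits printed from compound 1 to compound 4 (within the scatter) is what is estimated. For compound 4 the estimate is 16000 nM, with a range from 6000 nM to 40000 nM, and a real chance that only a limit is reported.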

Compound 4, inhibition constant: 17000 nM
Compound 4: the middle estimate sits 1.1-fold (0.03 log units) below what was measured; the measured number falls inside the stated range.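

In this assay, putting cyclobutyl in place of isopropyl on the aromatic nitrogen gives a 1.1-fold higher number from compound 1 to compound 4 (0.03 log units; within the scatter). Within the data shown here, this is the first step that can be read, and it shows that the two groups cannot be told apart at this position, even though cyclobutyl brings one more carbon and a four-membered ring. A real number also survives the exchange here, so this position now has a measured pair to build on.

Going by these compounds, whether another group on this nitrogen, such as a longer chain, a phenyl ring or a chain ending in an amine or a carboxylic acid, would move the value beyond the scatter stays open. Any such comparison would need values that are real numbers, and limits still make up much of what is shown: the limit of > 30000 nM in this assay, at which 2 of the 4 values shown sit.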